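Replacing a ring-bearing group with aminomethyl on the shared core

This account rests on a few compounds, and the source may have more. Where it says the series, first, only, none or still open, it means among the compounds named here.

In a functional assay with Oryctolagus cuniculus as the target (on this read-out lower numbers stand for stronger inhibition and higher numbers for weaker inhibition), compound 1 (`CNC(=N)Nc1nc(-c2ccc(OC)cc2)c(-c2ccc(OC)cc2)s1`) gives 62 nM, and compound 2 (`C/N=C(/NC)Nc1nc(-c2ccc(OC)cc2)c(-c2ccc(OC)cc2)s1`) gives 970 nM. Compound 3 (`COc1ccc(-c2nc(/N=C(\N)N3CCOCC3)sc2-c2ccc(OC)cc2)cc1`) is known only by a limit, < 1000 nM, so it has no exact place among these numbers.

The next structure, compound 4 (`COc1ccc(-c2nc(CN)sc2-c2ccc(OC)cc2)cc1`), changes compound 3 at one place: a group of 2 heavy atoms (1 carbon, 1 nitrogen; no ring) in place of a group of 9 heavy atoms (5 carbon, 3 nitrogen, 1 oxygen; one six-membered non-aromatic ring with 2 hetero atoms), on an aromatic carbon. Aminomethyl enters on an aromatic carbon of a five-membered aromatic ring with 1 nitrogen and 1 sulfur, and the shared 4-methoxyphenyl groups stay in place.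

For the measured compounds named here, only one measured step has a readable size: a 16-fold higher number from compound 1 to compound 2 (1.19 log units; beyond the scatter), a large step beyond the scatter. It shows that a small change at this place can move the number strongly in this assay. The other two, a step that the limit leaves unreadable from compound 1 to compound 3 and a step that the limit leaves unreadable from compound 2 to compound 3, give no size. None of the three compounds carries aminomethyl, so the evidence for the new group is indirect and the expected range must stay wide.

The expected step, set against a limit and not a number, is a step that the limit leaves unreadable from compound 3 to compound 4, and its direction is only tentatively expected. For compound 4 the estimated value is 500 nM, with an expected range from 50 nM to 4000 nM.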

Compound 4, half-maximal inhibitory concentration: > 100 nM
Compound 4: only a limit was reported; the forecaster's own chance of this, stated with the estimate: 25%; the middle value does not contradict the limit.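

Compound 4 is known in this assay only by a limit, > 100 nM. For the compounds shown here, the one readable step for aminomethyl on this aromatic carbon, next to the ring nitrogen and the ring sulfur, is an at least 1.6-fold higher number from compound 1 to compound 4 (0.20 log units; that floor lies within the scatter), so the result gives a floor for this change but does not set compound 4 apart from compound 1 beyond the scatter. The steps to compound 4 from compound 2 and from compound 3 cannot be read, because compound 4 is known only by a limit: the limit of > 100 nM in this assay, at which 1 of the 4 values shown sits.

Going by these compounds, the exact value of compound 4 remains open, and so does its order relative to compound 2 and compound 3. Also open, on these data alone, is whether a longer amine chain or a carboxylic acid in place of aminomethyl at this position would move the number in this assay.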